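This account rests on a few compounds, and the source may have more. Where it says the series, first, only, none or still open, it means among the compounds named here.

Of the compounds shown here, three built on one shared core have been measured in a functional assay on MOLT-4 cells (Homo sapiens) for inhibition; on this read-out higher numbers stand for weaker inhibition and lower numbers for stronger inhibition. Compound 1 `O=C1O/C(=C\Cn2cc(C(F)(F)F)c(=O)[nH]c2=O)C(OCc2ccccc2)=C1OCc1ccccc1` gives 900 nM, the lowest of the three numbers. Compound 2 `O=C1O/C(=C\Cn2cc(Br)c(=O)[nH]c2=O)C(OCc2ccccc2)=C1OCc1ccccc1` gives 3900 nM, and compound 3 `O=C1O/C(=C\Cn2cnc3c(-n4cccc4)ncnc32)C(OCc2ccccc2)=C1OCc1ccccc1` gives 3900 nM. Each of these lies a clear step above compound 1. Within the data shown here, the only pair that differs in a single place is the one with compound 2, and that step is a 4.3-fold higher number from compound 1 to compound 2 (0.64 log units; beyond the scatter).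

Compound 4 `O=C1O/C(=C\Cn2cc(Cl)c(=O)[nH]c2=O)C(OCc2ccccc2)=C1OCc1ccccc1` has not yet been measured. It differs from compound 1 in one place: chloro in place of trifluoromethyl on an aromatic carbon. Among the measured compounds shown here, one measured step bears on this change, because a 4.3-fold higher number from compound 1 to compound 2 (0.64 log units; beyond the scatter) also came from a halogen taking the position of the trifluoromethyl. That step was modest but beyond the scatter. For compound 4 the expected step is a 2.8-fold higher number from compound 1 to compound 4 (0.44 log units; beyond the scatter), in the same direction as that single halogen step. For the measured compounds named here, only one such step exists, so the range must be wide. Compound 4 is therefore estimated at 2500 nM, with a range from 900 nM to 7000 nM.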

Compound 4, half-maximal inhibitory concentration: 6100 nM
Estimate against measurement, compound 4: 2.4-fold (0.39 log units) below; the range from low to high includes it.
By their numbers in this assay, from the lowest: compound 1; then compounds 2, 3 and 4 (each within the scatter of the next).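

Swapping trifluoromethyl for chloro gives a 6.8-fold higher number from compound 1 to compound 4 (0.83 log units; beyond the scatter) in this assay, so a second halogen now moves the number the same way as bromo did in a 4.3-fold higher number from compound 1 to compound 2 (0.64 log units; beyond the scatter). Chloro and bromo cannot be told apart at this position, as a 1.6-fold higher number from compound 2 to compound 4 (0.19 log units; within the scatter) shows, which leaves trifluoromethyl as the one group of these three that stands apart. Nothing measured here explains why the number responds this way to the change.

The compounds shown leave open how a methyl, a fluoro or a nitrile would read on this same aromatic carbon, and so whether trifluoromethyl is alone in giving the lower number. They also leave open whether the step from trifluoromethyl to chloro keeps its size when another part of the shared core changes.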